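A few compounds are considered here, and "the series" means these few. Any claim that something is new, unique, unknown or untested is made for them only; others in the source may bear on it.

Measured so far:
Compound 1, `Cc1ccccc1N(C)C(=O)c1ccc(-c2ccc(OS(N)(=O)=O)c(Cl)c2)o1`: in an assay on T47D cells for inhibition of Steryl-sulfatase (Homo sapiens), read by HPLC, with a stated time of 24 h (on this read-out higher numbers stand for weaker inhibition and lower numbers for stronger inhibition), compound 1 gives 27 nM.
Compound 2, `Cc1ccccc1N(C)C(=O)c1ccc(-c2ccc(OS(N)(=O)=O)c(F)c2)o1`: in this assay compound 2 gives 17 nM.
Compound 3, `Cc1ccccc1N(C)C(=O)c1ccc(-c2ccc(OS(N)(=O)=O)cc2Cl)o1`: in this assay compound 3 gives 29 nM.

Among the compounds with values here, the one single-point change measured so far is from compound 1 to compound 2, (fluoro in place of chloro on an aromatic carbon); in this assay it gave a 1.6-fold lower number from compound 1 to compound 2 (0.20 log units; within the scatter). Compound 3 and compound 1 are built from the same atoms joined differently; the difference between the two cores is not broken down here. The values of compound 3 and compound 1 lie within the scatter of each other, and so do those of compound 3 and compound 2.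

Compound 4, `Cc1ccccc1N(C)C(=O)c1ccc(-c2ccc(OS(N)(=O)=O)cc2F)o1`, is not yet measured. It differs from compound 3 by fluoro in place of chloro on an aromatic carbon. This is the same kind of change as from compound 1 to compound 2, but the place is not the same: in compound 2 the fluoro stands ortho to a sulfamoyloxy group and meta to a large group, whereas in compound 4 it stands ortho to a large group and meta to a sulfamoyloxy group. Within the data shown here, the step expected in this assay is a 1.5-fold lower number from compound 3 to compound 4 (0.16 log units; within the scatter), resting on a 1.6-fold lower number from compound 1 to compound 2 (0.20 log units; within the scatter) as the only measured instance of this kind of change, with added width for the different place. Compound 4 is expected to give 20 nM, estimated to fall between 8 nM and 50 nM.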

Compound 4, half-maximal inhibitory concentration: 16 nM
Beside the measured number, compound 4's estimate is 1.3-fold (0.10 log units) above it; the measured number falls inside the stated range.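

Fluoro in place of chloro has now been read on two cores in this assay, and the new step is a 1.8-fold lower number from compound 3 to compound 4 (0.26 log units; within the scatter). Set beside the earlier step, the two agree: the same change on two cores in this assay, a 1.6-fold lower number (0.20 log units; within the scatter) from compound 1 to compound 2 and a 1.8-fold lower number (0.26 log units; within the scatter) from compound 3 to compound 4, 1.1-fold (0.06 log units) apart, within the scatter of two such steps. The change therefore carried from the core of compound 1 to the core of compound 3 with no step size that can be told apart, but each step lies within the scatter on its own, so this does not show that fluoro differs from chloro on either core, and two cores do not establish a rule for the wider series.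

The compounds shown leave open how other groups on the same aromatic carbons, such as hydrogen, methyl, methoxy or nitrile, would read in this assay. Also open, from the compounds shown here alone, is whether the sulfamoyloxy group can give way to a hydroxyl group, and what a longer chain in place of the methyl on the amide nitrogen would do.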